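Ester Tail Variation and Human Microsomal Half-Life

The source may hold more compounds than are shown below. What is called first, only, known or untested is meant among the compounds shown, and "the series" means these compounds.

Compound 1 `CCOc1cc(NC(=O)C2(NC(=O)c3ccc4c(C5CCCC5)c(-c5ncc(Cl)cn5)n(C)c4c3)CCC2)ccc1/C=C/C(=O)OCC(Cl)(Cl)Cl`: in an ADME assay (liver) for pharmacokinetics, with Liver microsome (Homo sapiens) as the target, using microsomes (a lower number here means that the compound disappears faster, a higher number that the compound lasts longer), compound 1 gives > 5 h, which is a limit of the assay rather than a number (the limit of > 5 h in this assay, at which 1 of the 3 values shown sits).
Compound 2 `CCOc1cc(NC(=O)C2(NC(=O)c3ccc4c(C5CCCC5)c(-c5ncc(Cl)cn5)n(C)c4c3)CCC2)ccc1/C=C/C(=O)OCCOCCOC`: in this assay compound 2 gives 0.85 h.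
Compound 3 `CCOc1cc(NC(=O)C2(NC(=O)c3ccc4c(C5CCCC5)c(-c5ncc(Cl)cn5)n(C)c4c3)CCC2)ccc1/C=C/C(=O)OCC(=O)OC`: in this assay compound 3 gives 2.1 h.

Compound 3 holds the highest of the two plain numbers shown; its nearest neighbour is compound 2, with a 2.5-fold higher number from compound 2 to compound 3 (0.39 log units; beyond the scatter). Compound 4 `CCOc1cc(NC(=O)C2(NC(=O)c3ccc4c(C5CCCC5)c(-c5ncc(Cl)cn5)n(C)c4c3)CCC2)ccc1/C=C/C(=O)OCC(=O)N1CCOCC1` differs from compound 3 by morpholin-4-yl in place of methoxy on a carbonyl carbon.

Going by the values given here, three measured steps bear on this region of the molecule, all of them on a saturated chain carbon bound to an oxygen next to a carbonyl group: an at least 5.8-fold lower number from compound 1 to compound 2 (0.76 log units; beyond the scatter), an at least 2.3-fold lower number from compound 1 to compound 3 (0.37 log units; beyond the scatter) and a 2.5-fold higher number from compound 2 to compound 3 (0.39 log units; beyond the scatter). Each is at least modest, so the tail of the ester clearly moves the half-life. None of them, however, exchanges methoxy for morpholin-4-yl on a carbonyl carbon, so the direction for compound 4 cannot be read directly from them; an expected step of a 1.2-fold higher number from compound 3 to compound 4 (0.08 log units; within the scatter), small and within or close to the scatter, is the most that can be estimated. Compound 4 is therefore expected at 2.5 h in this assay, with a range from 1 h to 6 h.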

Compound 4, half-life: 0.667 h
Estimate against measurement, compound 4: 3.7-fold (0.57 log units) above; the whole stated range lies above it.
By their numbers in this assay, from the lowest: compounds 4 and 2 (each within the scatter of the next); then compound 3. At a limit, above all of these: compound 1.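

With this change, the position proves sensitive to what sits on the carbonyl carbon itself, and not only to the choice of tail on the saturated chain carbon: in this assay, morpholin-4-yl in place of methoxy gives a 3.1-fold lower number from compound 3 to compound 4 (0.50 log units; beyond the scatter). The higher half-life that the methoxycarbonyl tail held over the (2-methoxyethoxy)methyl tail is not shared by the (morpholin-4-yl)carbonyl tail, for which the comparison reads a 1.3-fold lower number from compound 2 to compound 4 (0.11 log units; within the scatter), so two quite different tails cannot be told apart in this assay. The step from the trichloromethyl tail reads an at least 7.4-fold lower number from compound 1 to compound 4 (0.87 log units; beyond the scatter), and it is only a bound, as compound 1 sits at a limit of the assay: the limit of > 5 h in this assay, at which 1 of the 4 values shown sits.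

As far as these compounds go, it remains open whether the shorter half-life belongs to morpholin-4-yl in particular or would follow other groups on this carbonyl carbon, such as dimethylamino, piperidin-1-yl or a hydroxyl group completing a carboxylic acid. Also open, from the compounds shown here alone, is how much of the long half-life of compound 1 rests on its three chlorine atoms, which a trifluoromethyl group or a plain methyl group on the saturated chain carbon would begin to answer.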